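Furan for Thiazole at the End of a Longer Polyene

The source may hold more compounds than are shown below. What is called first, only, known or untested is meant among the compounds shown, and "the series" means these compounds.

Compound 1 `CCOC(=O)/C=C/C=C/C=C/c1nccs1` gives 4500 nM in a functional assay on CCRF-CEM cells (Homo sapiens) for cytotoxicity, with a stated time of 72 h; on this read-out lower numbers stand for stronger inhibition and higher numbers for weaker inhibition.
Compound 2 `CCOC(=O)/C=C/C=C/C=C/C=C/c1nccs1` gives > 10000 nM, which is a limit of the assay and not a number.
Compound 3 `CCOC(=O)/C=C/C=C/C=C/c1ccco1` gives > 10000 nM, likewise a limit of the assay.

The three measured compounds share a core carrying a conjugated chain that ends in a five-membered aromatic ring. Compound 1 and compound 2 differ in the length of that chain, but the difference between the two cores is not broken down here. Compound 1 and compound 3 differ in one place only: furan-2-yl in place of 1,3-thiazol-2-yl on a double-bonded chain carbon bound to a double-bonded chain carbon. This change made an at least 2.2-fold higher number from compound 1 to compound 3 (0.34 log units; beyond the scatter), a step toward weaker inhibition. Two of the three values already sit at the limit of > 10000 nM in this assay, at which 2 of the 3 values shown sit, so the assay gives little room to see further weakening.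

Compound 4 `CCOC(=O)/C=C/C=C/C=C/C=C/c1ccco1` has not yet been measured. It stands to compound 2 exactly as compound 3 stands to compound 1: furan-2-yl in place of 1,3-thiazol-2-yl on a double-bonded chain carbon bound to a double-bonded chain carbon. The same change is therefore being made on the longer core. Resting on the measured step of an at least 2.2-fold higher number from compound 1 to compound 3 (0.34 log units; beyond the scatter), the expected step is a step that the limit leaves unreadable from compound 2 to compound 4, that is, no gain in inhibition. Since compound 2 is already reported only as a limit, compound 4 is expected to be reported as a limit as well in this assay, with an estimated value of 20000 nM, lying between 8000 nM and 60000 nM.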

Compound 4, half-maximal inhibitory concentration: > 10000 nM
Compound 4: a limit, no number; the forecaster's own chance of this, stated with the estimate: 90%; the middle value lies beyond the limit too.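

In this assay compound 4 gives > 10000 nM, which is a limit of the assay and not a number. Compound 2 is also reported only as a limit, so no step from compound 2 to compound 4 can be read: the limit of > 10000 nM in this assay, at which 3 of the 4 values shown sit.

The compounds shown leave open how far compound 2 and compound 4 lie past that limit, and whether furan-2-yl in place of 1,3-thiazol-2-yl weakens inhibition on the longer core as it did on the shorter one.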